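The source may hold more compounds than are shown below. What is called first, only, known or untested is meant among the compounds shown, and "the series" means these compounds.

Of the compounds shown here, three built on one shared core have so far been tested in an assay on isolated protein for agonist activity at Bile acid receptor (Homo sapiens), read by AlphaScreen, with a stated time of 30 min; on this read-out higher numbers stand for an effect only at larger amounts of compound and lower numbers for an effect already at smaller amounts. Compound 1 `Cc1ccccc1-n1nc(C)c2c1NC(=O)[C@H](C)S[C@@H]2c1ccc(-c2cccc(C(=O)O)c2)cc1` was reported as "not active" (no number reported), with no number attached. Compound 2 `COc1ccccc1-n1nc(C)c2c1NC(=O)[C@H](C)S[C@@H]2c1ccc(Oc2ccccc2)cc1` gives 3300 nM, and compound 3 `COc1ccc(C2SC(C)C(=O)Nc3c2c(C)nn3-c2ccccc2C)c(OC)c1` gives 10500 nM. Of the two numbers available, compound 2 stands lowest, and its gap to compound 3 lies beyond the scatter of repeated measurements, so compound 2 is the one that acts already at smaller amounts.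

Compound 4 `Cc1ccc(-n2nc(C)c3c2NC(=O)[C@H](C)S[C@@H]3c2ccc(Oc3ccccc3)cc2)cc1` has not yet been measured in this assay. It differs from compound 2 in one place only: 4-methylphenyl in place of 2-methoxyphenyl on an aromatic nitrogen. Within the data shown here, no pair of measured compounds isolates this particular change, since compound 1 and compound 3 each differ from compound 2 at more than one place, so the direction of the step cannot be read from the data directly. The expectation is therefore a cautious one: a step from compound 2 to compound 4 of a 1.7-fold higher number from compound 2 to compound 4 (0.22 log units; within the scatter), somewhat toward higher numbers, but small enough that it may well fall within the scatter. On that basis compound 4 is estimated to give 5500 nM in this assay, with a plausible range from 1500 nM to 20000 nM.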

Compound 4, half-maximal effective concentration: 3400 nM
For compound 4 the middle estimate is 1.6-fold (0.21 log units) above the measured one; measured number inside the range.
By their numbers in this assay, from the lowest: compounds 2 and 4 (each within the scatter of the next); then compound 3.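

Among these compounds, putting 4-methylphenyl in place of 2-methoxyphenyl on the aromatic nitrogen, with the rest of the molecule unchanged, gives in this assay a result that can be read directly for the first time (a 1.0-fold higher number from compound 2 to compound 4 (0.01 log units; within the scatter)). The two numbers cannot be told apart, even though 2-methoxyphenyl carries a hydrogen-bond acceptor and 4-methylphenyl carries none, and the two groups differ in their substituent and in where it stands on the ring. So, for this pair at least, the exchange leaves the read-out unmoved, and no measurement at hand accounts for that outcome.

Both groups compared here are six-membered aromatic rings of carbon only, each with one small substituent, so this single pair cannot say how far that tolerance reaches. Open questions include whether a carboxylic acid or an amine on this ring would leave the number in the same place, and whether a plain phenyl, a ring containing nitrogen or a simple alkyl chain on the aromatic nitrogen would do the same.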